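This account rests on a few compounds, and the source may have more. Where it says the series, first, only, none or still open, it means among the compounds named here.

Measured in an ADME assay on MDCK cells (Canis lupus familiaris) for cytotoxicity, read by MTT assay, with a stated time of 72 h (a lower number here means a stronger inhibitor, a higher number a weaker inhibitor), so far
- Compound 1 `COc1ccc(/C=C/c2cc(C)n[nH]2)cc1` at 16500 nM
- Compound 2 `COc1ccc(/C=C/c2cc(C)no2)cc1OC` at 44700 nM
- Compound 3 `COc1ccc(/C=C/C(=O)CC(C)=O)cc1OC` at 9900 nM

Compound 3 and compound 1 lie within the usual scatter of each other, while compound 2 stands apart from compound 3 by a margin beyond that scatter. Compound 4 `COc1ccc(/C=C/c2cc(C)n[nH]2)cc1OC` has not yet been measured. It differs from compound 3 by 3-methyl-1H-pyrazol-5-yl in place of (2-oxopropyl)carbonyl on a double-bonded chain carbon bound to a double-bonded chain carbon in the one place, so the open-chain group gives way to a five-membered aromatic ring.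

For the measured compounds named here, only one measured step changes this same place, and it does so with a different ring: a 4.5-fold lower number from compound 2 to compound 3 (0.65 log units; beyond the scatter) as (2-oxopropyl)carbonyl replaces 3-methyl-1,2-oxazol-5-yl. Read backwards, that modest step suggests that a ring here may raise the number. Compound 1 carries the incoming 3-methyl-1H-pyrazol-5-yl group on a core of its own and gives 16500 nM in this assay as the closest guide. Going by the values given here, no measured pair isolates this exact exchange, so a modest upward step is expected, smaller than the one seen with compound 2. The estimate means a 2.1-fold higher number from compound 3 to compound 4 (0.33 log units; beyond the scatter) as the expected step. For compound 4 the estimated value is 21000 nM with an expected range from 9000 nM to 48000 nM in this assay.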

Compound 4, half-maximal inhibitory concentration: 54100 nM
For compound 4 the middle estimate is 2.6-fold (0.41 log units) below the measured one; the whole stated range lies below it.
By their numbers in this assay, from the lowest: compounds 3 and 1 (each within the scatter of the next); then compounds 2 and 4 (each within the scatter of the next).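

In this assay, the step of a 5.5-fold higher number from compound 3 to compound 4 (0.74 log units; beyond the scatter) shows that a second five-membered aromatic ring in this place also goes with a higher number than the open-chain (2-oxopropyl)carbonyl, so the earlier step with 3-methyl-1,2-oxazol-5-yl no longer stands alone. The two rings cannot be told apart here, with a 1.2-fold higher number from compound 2 to compound 4 (0.08 log units; within the scatter), so exchanging 3-methyl-1,2-oxazol-5-yl for 3-methyl-1H-pyrazol-5-yl, which adds a hydrogen-bond donor to the count, brings no change beyond the scatter. The result also shows that this series responds to a change elsewhere, since methoxy in place of hydrogen on an aromatic carbon gives a 3.3-fold higher number from compound 1 to compound 4 (0.52 log units; beyond the scatter), a change beyond the scatter that is seen with this one ring only.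

Nothing available explains why the open-chain group gives the lower number. The compounds shown leave open whether that lower number belongs to (2-oxopropyl)carbonyl in particular or would extend to other open-chain groups such as a carboxylic acid or a longer chain, and whether the methoxy step would recur with 3-methyl-1,2-oxazol-5-yl or (2-oxopropyl)carbonyl in place of the pyrazolyl ring.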